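The source may report more compounds than this note shows. Statements on the series, on what has been measured and on what is new or still open speak of the compounds shown alone.

Compound 3 `CCOc1ccc(-n2nncc2CN2C(=O)C3(C(C#N)=C(N)Oc4c(N)cc5nc6ccccc6nc5c43)c3ccccc32)cc1` was tested in a functional assay on HepG2 cells (Homo sapiens) for antiproliferative activity, read by MTT assay, with a stated time of 48 h; on this read-out lower numbers stand for stronger inhibition and higher numbers for weaker inhibition. Its result is not a number but a limit of the assay, > 50000 nM, as summed up in the limit of > 50000 nM in this assay, at which 1 of the 3 values shown sits. Two close relatives give numbers: compound 1 `N#CC1=C(N)Oc2c(N)cc3nc4ccccc4nc3c2C12C(=O)N(Cc1cnnn1-c1ccccc1Cl)c1ccccc12`, which carries a 2-chlorophenyl on the same aromatic nitrogen, gives 33500 nM, and compound 2 `N#CC1=C(N)Oc2c(N)cc3nc4ccccc4nc3c2C12C(=O)N(Cc1cnnn1-c1ccccc1Br)c1ccccc12`, with a 2-bromophenyl there, gives 38000 nM. The step from compound 1 to compound 3 is an at least 1.4-fold higher number from compound 1 to compound 3 (0.17 log units; that floor lies within the scatter), and the step from compound 2 to compound 3 is an at least 1.3-fold higher number from compound 2 to compound 3 (0.11 log units; that floor lies within the scatter); both floors lie within the scatter, so swapping the aryl group on this nitrogen has so far moved the read-out little.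

Compound 4 `Cc1ccc(C)c(-n2nncc2CN2C(=O)C3(C(C#N)=C(N)Oc4c(N)cc5nc6ccccc6nc5c43)c3ccccc32)c1` is the next swap on this nitrogen: 2,5-dimethylphenyl in place of 4-ethoxyphenyl on an aromatic nitrogen. With only small, scatter-level steps to go on, no shift beyond the scatter is expected; the estimated step is an at least 1.2-fold lower number from compound 3 to compound 4 (0.09 log units; that floor lies within the scatter). Compound 4 is therefore expected to give about 40000 nM, within a range of 20000 nM to 100000 nM, with a real chance that only a limit is reported again.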

Compound 4, half-maximal inhibitory concentration: > 50000 nM
Compound 4 gave a limit, no number; the forecaster's own chance of this, stated with the estimate: 45%; middle value at least 1.2-fold (0.09 log units) from the limit.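

In this assay, compound 4 also gives a limit of the assay and not a number, so a 2,5-dimethylphenyl, which has no oxygen, does not yield a readable value any more than the 4-ethoxyphenyl of compound 3 did, and the step between these two compounds cannot be read. Against the halogen-bearing compounds, the result is an at least 1.3-fold higher number from compound 2 to compound 4 (0.11 log units; that floor lies within the scatter) and an at least 1.4-fold higher number from compound 1 to compound 4 (0.17 log units; that floor lies within the scatter), so neither comparison shows a shift beyond the scatter. The same limit now recurs among the aryl groups on this nitrogen: the limit of > 50000 nM in this assay, at which 2 of the 4 values shown sit.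

Going by these compounds, how far compound 3 and compound 4 lie past that limit remains open, so these aryl groups cannot be ranked against each other. Also open, on these data alone, is whether a phenyl carrying a carboxylic acid or an amine, or a longer alkyl chain in place of the aryl ring, would give a lower number.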